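Azole swap on the indole core: triazolyl to imidazolyl

A few compounds are considered here, and "the series" means these few. Any claim that something is new, unique, unknown or untested is made for them only; others in the source may bear on it.

Two compounds of the series have numbers in an assay on CHO cells for displacement of a labelled ligand from 5-hydroxytryptamine receptor 1D (Homo sapiens); on this read-out higher numbers stand for weaker inhibition and lower numbers for stronger inhibition. Compound 2 `C[C@@H](NC1CCN(CCCc2c[nH]c3ccc(-n4cnnc4)cc23)CC1)c1ccccc1` gives 0.4 nM. Compound 1 `OC[C@H](NC1CCN(CCCc2c[nH]c3ccc(-n4ccnc4)cc23)CC1)c1ccccc1` carries a hydroxymethyl group on the side chain and an imidazolyl group on the core, and in this assay compound 1 gives 0.7 nM. The two values sit within the usual scatter of each other, so no order between compound 1 and compound 2 can be read from them.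

Compound 3 `C[C@@H](NC1CCN(CCCc2c[nH]c3ccc(-n4ccnc4)cc23)CC1)c1ccccc1` keeps the methyl side chain of compound 2 and changes only the azole: 1H-imidazol-1-yl in place of 4H-1,2,4-triazol-4-yl on an aromatic carbon. For the measured compounds named here, no measured pair isolates this change, so the size of the step has to be judged from the fact that both azoles already appear in compounds with sub-nanomolar numbers in this assay. The step from compound 2 to compound 3 is expected to be small and of no clear direction, likely none beyond the scatter, as a 1.3-fold higher number from compound 2 to compound 3 (0.10 log units; within the scatter). For compound 3 the expected value in this assay is 0.5 nM, with a range from 0.2 nM to 1.2 nM.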

Compound 3, half-maximal inhibitory concentration: 4.2 nM
Estimate against measurement, compound 3: 8.4-fold (0.92 log units) below, and the stated range ends below it.
By their numbers in this assay, from the lowest: compounds 2 and 1 (each within the scatter of the next); then compound 3.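

With the methyl side chain held constant in this assay, the azole on the aromatic carbon proves not to be a neutral exchange: 1H-imidazol-1-yl in place of 4H-1,2,4-triazol-4-yl gives an 11-fold higher number from compound 2 to compound 3 (1.02 log units; beyond the scatter), although both rings have 5 heavy atoms and differ by one ring nitrogen replaced with carbon. With the 1H-imidazol-1-yl group held constant, the amine substituent also counts: 1-phenylethyl in place of 2-hydroxy-1-phenylethyl gives a 6.0-fold higher number from compound 1 to compound 3 (0.78 log units; beyond the scatter), a modest step but one beyond the scatter. Compound 1 and compound 2 differ in both places, so neither contribution could be read from that pair, and no measurement at hand accounts for either step.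

Open, on these data alone, is whether the two steps add up when 4H-1,2,4-triazol-4-yl and 2-hydroxy-1-phenylethyl stand on the shared core. Also open, as far as these compounds go, is how a tetrazolyl ring on the same aromatic carbon, or a methoxymethyl group or a carboxylic acid in place of the hydroxymethyl group, would read in this assay.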